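A Third Substituent on the Shared Core

The source may hold more compounds than are shown below. What is called first, only, known or untested is meant among the compounds shown, and "the series" means these compounds.

Compound 3 `CCSCc1c(C)nc2c(OCc3ccccc3)cccn12` gives 0% in a functional assay on the whole organism (stomach) for inhibition, with Canis familiaris (Canis lupus familiaris) as the target, at a dose of 5 mg/kg by the intravenous route (a higher number here means a stronger effect of the compound at the dose given, a lower number a weaker effect), the lowest of the three numbers. Compound 2 `CC(=O)c1c(C)nc2c(OCc3ccccc3)cccn12` stands nearest to it with 9%, and a number 9 percentage points lower from compound 2 to compound 3 (within the scatter). Compound 1 `Cc1cn2cccc(OCc3ccccc3)c2n1` gives 70%, and a number 70 percentage points lower from compound 1 to compound 3 (beyond the scatter). Compound 4 `COC(=O)Cc1c(C)nc2c(OCc3ccccc3)cccn12` differs from compound 3 by methoxycarbonyl in place of ethylsulfanyl on a saturated chain carbon bound to an aromatic carbon. For the measured compounds named here, two measured steps bear on this: placing either acetyl or (ethylsulfanyl)methyl on the aromatic carbon lowered the read-out by a large amount, as seen in a number 61 percentage points lower from compound 1 to compound 2 (beyond the scatter) and a number 70 percentage points lower from compound 1 to compound 3 (beyond the scatter), while exchanging one of these groups for the other moved nothing beyond the scatter. A further group on that carbon is therefore expected to leave the read-out near the bottom, with a number 5 percentage points higher from compound 3 to compound 4 (within the scatter). Compound 4 is expected to give 5%, between 0% and 25%.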

Compound 4, a percentage reported as inhibition, in the whole organism at one dose (the size of the read-out at that dose, not a potency): 16%
Beside the measured number, compound 4's estimate is 11 percentage points below it; the measured number falls inside the stated range.
By their numbers in this assay, from the lowest: compounds 3, 2 and 4 (each within the scatter of the next, the first and the last beyond it); then compound 1.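

Among the three compounds with a group on that aromatic carbon, only one step in this assay leaves the scatter: a number 16 percentage points higher from compound 3 to compound 4 (beyond the scatter), when methoxycarbonyl replaces ethylsulfanyl on the saturated chain carbon. The other comparison within this set shows a number 7 percentage points higher from compound 2 to compound 4 (within the scatter), while a number 54 percentage points lower from compound 1 to compound 4 (beyond the scatter) confirms that the large loss remains with (methoxycarbonyl)methyl on that carbon. Nothing available explains these differences. Going by these compounds, whether a carboxylic acid or an amine on that chain would recover more of the read-out remains open, as does the effect of a longer chain.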